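Chloro for trifluoromethyl in a level series

This account rests on a few compounds, and the source may have more. Where it says the series, first, only, none or still open, it means among the compounds named here.

In a functional assay on DU-145 cells (Homo sapiens) for inhibition, read by trypan blue exclusion, with a stated time of 96 h (on this read-out lower numbers stand for stronger inhibition of growth and higher numbers for weaker inhibition of growth), compound 1 (`CN(C)c1ccc(/C=C(/SCc2ccc(Cl)cc2)C(=O)c2ccc(C(=O)O)cc2)cc1`) gives 1000 nM and compound 2 (`O=C(O)c1ccc(C(=O)/C(=C\c2ccc(Cl)c([N+](=O)[O-])c2)SCc2ccc(Cl)cc2)cc1`) gives 1000 nM as well. Compound 3 (`O=C(O)c1ccc(C(=O)/C(=C\c2ccc(F)c([N+](=O)[O-])c2)SCc2ccc(C(F)(F)F)cc2)cc1`) at 1000 nM stands level with both at the digits available, so the numbers place it neither ahead of them nor behind them.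

Compound 4 (`O=C(O)c1ccc(C(=O)/C(=C\c2ccc(F)c([N+](=O)[O-])c2)SCc2ccc(Cl)cc2)cc1`) has not yet been measured. It differs from compound 3 in one place, para to a large group (chloro in place of trifluoromethyl on an aromatic carbon), so that 4-(trifluoromethyl)benzyl becomes 4-chlorobenzyl.

Among the compounds with values here, no measured step isolates this exchange. Within the data shown here, the only single-place step available lies elsewhere in the molecule (no change at the digits printed from compound 1 to compound 2 (within the scatter)) and puts 4-chloro-3-nitrophenyl in place of 4-(dimethylamino)phenyl. It bears on the question only indirectly, as a sign of how little the read-out has moved so far. Among the measured compounds shown here, with only this evidence, and with compound 3 at 1000 nM as the starting point, no step beyond the scatter is expected.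

The expected step is small (no change at the digits printed from compound 3 to compound 4 (within the scatter)) and is estimated to stay within the scatter. For compound 4 the estimated value is 1000 nM with an expected range from 500 nM to 2000 nM in this read-out.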

Compound 4, concentration for 50% growth inhibition: 50000 nM
Compound 4: the middle estimate sits 50-fold (1.70 log units) below what was measured; the whole stated range lies below it.
By their numbers in this assay, from the lowest: compounds 1, 2 and 3 (each within the scatter of the next); then compound 4.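

In this assay, the aromatic carbon para to a large group proves to be a position that matters in this series: chloro in place of trifluoromethyl gives a 50-fold higher number from compound 3 to compound 4 (1.70 log units; beyond the scatter), the first change shown to move the read-out beyond the scatter. The other halogen site responds as well, since fluoro in place of chloro on an aromatic carbon gives a 50-fold higher number from compound 2 to compound 4 (1.70 log units; beyond the scatter), and with 4-chlorobenzyl held fixed, 4-fluoro-3-nitrophenyl in place of 4-(dimethylamino)phenyl gives a 50-fold higher number from compound 1 to compound 4 (1.70 log units; beyond the scatter), although 4-chloro-3-nitrophenyl in that same place gave no change at the digits printed from compound 1 to compound 2 (within the scatter). Within the data shown here, the level values of the earlier compounds therefore did not mean that these sites are indifferent, as one halogen exchange at either site is enough to set compound 4 apart from a compound that differs from it in that one place.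

Nothing available accounts for the size of these steps. Going by these compounds, it remains open whether the loss follows chloro alone or only its pairing with 4-fluoro-3-nitrophenyl, and whether a bromo, a methyl or a methoxy on the same aromatic carbon would read like compound 3 or like compound 4.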